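Swapping a Chloro Heteroaryl for a Bromo Heteroaryl

The compounds below may be only part of what the source reports. "The series", "measured", "known", "first", "only" and "open" are said of these compounds alone.

Measured so far:
Compound 1, `O=C1NC(O)(/C=C\n2cc(I)c3c(Cl)ncnc32)C(OCc2ccccc2)=C1OCc1ccccc1`: 22600 nM
Compound 2, `O=C1NC(O)(CCn2cnc3ccnc(Cl)c32)C(OCc2ccccc2)=C1OCc1ccccc1`: 60000 nM

Of the compounds shown here, two have been tested in a functional assay on MIA PaCa-2 cells (Homo sapiens) for antiproliferative activity, read by MTT assay, with a stated time of 72 h; a higher number here means a weaker inhibitor, a lower number a stronger inhibitor. Compound 1 gives 22600 nM in this assay. Compound 2 gives 60000 nM, the highest of the two numbers shown; its nearest neighbour is compound 1, whose lower number lies beyond the usual scatter of such measurements. Both compounds share the same core, a saturated ring bearing two benzyloxy groups and a hydroxyl, and differ only in the heteroaryl group on the chain.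

Compound 3, `O=C1NC(O)(CCn2cnc3cncc(Br)c32)C(OCc2ccccc2)=C1OCc1ccccc1`, has not yet been measured. It is built from compound 2 by a single change: a group of 10 heavy atoms (6 carbon, 3 nitrogen, 1 bromine; one five-membered aromatic ring with 2 hetero atoms, one six-membered aromatic ring with 1 hetero atom) in place of a group of 10 heavy atoms (6 carbon, 3 nitrogen, 1 chlorine; one five-membered aromatic ring with 2 hetero atoms, one six-membered aromatic ring with 1 hetero atom), on a saturated chain carbon, two bonds along the chain from a saturated ring carbon. Going by the values given here, no measured pair in this small set shows the effect of such a change, so there is no direct precedent to lean on. With both measured compounds already weak and the change limited to a halogen and the arrangement of the ring atoms, the expected step from compound 2 to compound 3 in this assay is a 1.2-fold lower number from compound 2 to compound 3 (0.08 log units; within the scatter), which is not expected to exceed the scatter. Compound 3 is therefore estimated at 50000 nM, with a range from 15000 nM to 150000 nM.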

Compound 3, half-maximal inhibitory concentration: 48700 nM
Compound 3: middle estimate off by 1.0-fold (0.01 log units), on the high side; the range from low to high includes it.
By their numbers in this assay, from the lowest: compound 1; then compounds 3 and 2 (each within the scatter of the next).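

In this assay, going by these compounds alone, replacing the chlorine-bearing group of compound 2 with the bromine-bearing group of compound 3 gives a 1.2-fold lower number from compound 2 to compound 3 (0.09 log units; within the scatter) and provides the first direct comparison at this position, on a saturated chain carbon, two bonds along the chain from a saturated ring carbon. This single pair shows that the change, which alters both the halogen and the arrangement of atoms in the heteroaryl group, leaves the two compounds indistinguishable in this measurement, so neither can be ranked above the other. No supporting measurement is available to explain this result.

Because the halogen and the ring-atom arrangement change together, the pair cannot show what each does alone, and a matching pair that changes only one of them would be needed to separate them. As far as these compounds go, it also remains open whether a more different group at this position, such as an amine or a carboxylic acid in place of the halogen, or a longer chain leading to the heteroaryl group, would produce a step beyond the scatter.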